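The source may hold more compounds than are shown below. What is called first, only, known or untested is meant among the compounds shown, and "the series" means these compounds.

In a physicochemical assay for solubility, at pH 6.8 (a higher number here means a more soluble compound, a lower number a less soluble compound), compound 1 `COC(C)(C)CCOc1cccc(OCc2[nH]c3ccccc3c(=O)c2C)c1` gives 2000 nM and compound 2 `Cc1c(COc2cccc(OCC3CCOCC3)c2)[nH]c2ccccc2c1=O` gives 5000 nM, the higher of the two numbers. Still unmeasured, compound 3 `Cc1ccc2[nH]c(COc3cccc(OCC4CCOCC4)c3)c(C)c(=O)c2c1` differs from compound 2 by methyl in place of hydrogen on an aromatic carbon. Among the compounds with values here, the only measured step, a 2.5-fold higher number from compound 1 to compound 2 (0.40 log units; beyond the scatter), was modest and lay at a different place, so it offers only a rough scale. A modest move to a lower number is expected in this assay, and the estimated step is a 1.7-fold lower number from compound 2 to compound 3 (0.22 log units; within the scatter). For compound 3 the estimated value is 3000 nM, with an expected range of 1000 nM to 7000 nM.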

Compound 3, solubility: < 1000 nM
Compound 3 was reported as a limit; the forecaster's own chance of this, stated with the estimate: 5%; at least 3.0-fold (0.47 log units) between middle value and limit.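

In this assay compound 3 gives < 1000 nM, which is a limit of the assay and not a number. The earlier compounds shown here differed only in the group on the saturated chain, whereas this change lies on the shared core: a single methyl in place of hydrogen, on an aromatic carbon meta to a fused ring and para to a fused ring, comes with an at least 5.0-fold lower number from compound 2 to compound 3 (0.69 log units; beyond the scatter). The full size of that step cannot be read: the limit of < 1000 nM in this assay, at which 1 of the 3 values shown sits.

Going by these compounds, whether a chlorine or a methoxy group on this same carbon would come with a step of like size stays open. So does whether a methyl on the other carbons of that ring would.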